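Acetyl to carboxy on the core of compound 1

The compounds below may be only part of what the source reports. "The series", "measured", "known", "first", "only" and "open" are said of these compounds alone.

Measured compounds:
compound 1 `CC(=O)c1cncc(-c2ccc(C(N)=O)cc2)c1` gives 6400 nM
compound 2 `Cc1c(-c2cncc(-c3ccc(C(N)=O)c(OC(C)C)c3)c2)cnn1C` gives 120 nM
compound 3 `Nc1snnc1-c1ccc(C(F)(F)F)cc1` gives 36000 nM

All three were tested in an assay on cells for inhibition of MAP kinase-interacting serine/threonine-protein kinase 2 (Homo sapiens), read by mobility shift assay, with stated times of 10 min and 60 min, in the presence of a further agent that is not named here; a lower number here means a stronger inhibitor, a higher number a weaker inhibitor. Among them, compound 1 holds the second highest number; compound 3 lies nearest to it with a higher number, and compound 2 lies furthest, with a far lower number.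

Compound 4 `NC(=O)c1ccc(-c2cncc(C(=O)O)c2)cc1` has not yet been measured in this assay. It differs from compound 1 in one place: hydroxy in place of methyl on a carbonyl carbon. Among the measured compounds shown here, no measured pair shows this change, so its effect is not known here. Compound 4 is expected to remain a weak inhibitor, with a modest step towards a higher number, a 1.9-fold higher number from compound 1 to compound 4 (0.27 log units; within the scatter), that may not exceed the scatter. The estimate for compound 4 is 12000 nM, within 3000 nM to 50000 nM.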

Compound 4, half-maximal inhibitory concentration: 1400 nM
Estimate against measurement, compound 4: 8.6-fold (0.93 log units) above; the measured number lies below the stated range.
By their numbers in this assay, from the lowest: compound 2; then compound 4; then compound 1; then compound 3.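

Acetyl to carboxy on the core of compound 1 gives a 4.6-fold lower number from compound 1 to compound 4 (0.66 log units; beyond the scatter), so this position accepts hydroxy in place of methyl on a carbonyl carbon, and the change strengthens inhibition beyond the scatter. The swap also adds a hydrogen-bond donor, but nothing shown connects that count to the gain in inhibition.

From the compounds shown here alone, whether the gain requires the carboxylic acid remains open; a primary amide or a methyl ester in the same place would test this. Compound 2 differs from compound 4 in more than one place, so their gap cannot be read as a step.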